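A few compounds are considered here, and "the series" means these few. Any claim that something is new, unique, unknown or untested is made for them only; others in the source may bear on it.

Compound 1 `COCOc1ccc2c(c1)OC(c1ccc(OC)c(CC=C(C)C)c1)CC2=O`: 7670 nM
Compound 2 `COc1ccc2c(c1)OC(c1ccc(OC)c(CC=C(C)C)c1)CC2=O`: 3670 nM

Among the measured compounds shown here, in an assay on isolated protein for inhibition of Aromatase (Homo sapiens) (on this read-out lower numbers stand for stronger inhibition and higher numbers for weaker inhibition), compound 2 stands lowest of the two numbers; the only measured step, a 2.1-fold lower number from compound 1 to compound 2 (0.32 log units; beyond the scatter), is modest. Compound 3 `COc1ccc(C2CC(=O)c3ccccc3O2)cc1CC=C(C)C` differs from compound 2 by hydrogen in place of methoxy on an aromatic carbon. That step bears only loosely on it, since the measured step removed a methoxy on a saturated chain carbon bound to an oxygen on an aromatic ring, not on the ring itself. For compound 3 a step no larger than a 1.4-fold higher number from compound 2 to compound 3 (0.13 log units; within the scatter) is expected, in either direction. Compound 3 is therefore estimated at 5000 nM, between 2000 nM and 15000 nM.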

Compound 3, half-maximal inhibitory concentration: 12100 nM
Estimate against measurement, compound 3: 2.4-fold (0.38 log units) below; the range from low to high includes it.
By their numbers in this assay, from the lowest: compound 2; then compounds 1 and 3 (each within the scatter of the next).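

In this assay, replacing methoxy on this aromatic carbon with hydrogen gives a 3.3-fold higher number from compound 2 to compound 3 (0.52 log units; beyond the scatter), so the group on the ring does bear on the read-out. Replacing methoxymethoxy at the same carbon with hydrogen gives a 1.6-fold higher number from compound 1 to compound 3 (0.20 log units; within the scatter), so among these three groups only methoxy stands apart, and an oxygen at this carbon is not enough on its own. Nothing available explains why methoxy differs here. Open, as far as these compounds go, is how a hydroxyl, an ethoxy or a fluorine at this carbon would compare with methoxy.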